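Swapping the benzoyl substituent in a piperidine sulfonamide series

The source may hold more compounds than are shown below. What is called first, only, known or untested is meant among the compounds shown, and "the series" means these compounds.

Compound 2, `CS(=O)(=O)c1ccccc1C(=O)N1CCC(N(C2CC2)S(=O)(=O)c2cccc(C(F)(F)F)c2)CC1`, was examined in an assay on cells for inhibition of Voltage-dependent L-type calcium channel subunit alpha-1C (Homo sapiens), read by FLIPR and calcium flux, tested at 1 uM (on this read-out higher numbers stand for a stronger effect at the one concentration tested and lower numbers for a weaker effect), where compound 2 gives 19%. Its closest measured relative is compound 1, `CS(=O)(=O)c1ccc(F)cc1C(=O)N1CCC(N(C2CC2)S(=O)(=O)c2cccc(C(F)(F)F)c2)CC1`, which in this assay gives 18%; the step of a number 1 percentage points higher from compound 1 to compound 2 (within the scatter) replaces hydrogen with fluoro on an aromatic carbon and falls within the scatter, so compound 2 and compound 1 cannot be told apart on these two numbers. Compound 3, `CN(C)c1cccc(C(=O)N2CCC(N(C3CC3)S(=O)(=O)c3cccc(C(F)(F)F)c3)CC2)c1`, has not yet been measured. It differs from compound 2 by 3-(dimethylamino)phenyl in place of 2-(methylsulfonyl)phenyl on a carbonyl carbon. Within the data shown here, no measured step touches this position of the molecule: the only step available concerns the aromatic fluoro, and it was flat. Nothing therefore points to a change in either direction, and the estimate rests on compound 2 alone. The expected step is a number 1 percentage points higher from compound 2 to compound 3 (within the scatter), with wide uncertainty. Compound 3 is accordingly estimated at 20%, within a range from 0% to 45%.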

Compound 3, a percentage reported as inhibition, at one concentration (the size of the read-out at that concentration, not a potency): 40%
For compound 3 the middle estimate is 20 percentage points below the measured one; the measured number falls inside the stated range.
By their numbers in this assay, from the lowest: compounds 1 and 2 (each within the scatter of the next); then compound 3.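

In this assay the position on the carbonyl carbon proves responsive: exchanging 2-(methylsulfonyl)phenyl for 3-(dimethylamino)phenyl gives a number 21 percentage points higher from compound 2 to compound 3 (beyond the scatter) and exchanging 5-fluoro-2-(methylsulfonyl)phenyl for the same group gives a number 22 percentage points higher from compound 1 to compound 3 (beyond the scatter) on the same read-out. Among these compounds, the aromatic fluoro step had stayed within the scatter, so this is the first change to move the number beyond it, although the effect remains modest and comes from a single concentration. Nothing available explains the rise.

The exchange replaces a whole aryl group, so the compounds shown cannot separate what the dimethylamino group contributes from what the loss of the methylsulfonyl group contributes. On these data alone, it also remains open how a plain phenyl, a primary amine or a carboxylic acid on the carbonyl carbon's aryl group would read.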